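The compounds below may be only part of what the source reports. "The series", "measured", "known", "first", "only" and "open" are said of these compounds alone.

Measured so far in a functional assay for inhibition, read by spectrophotometry, with a stated time of 20 min, tested at 4 mg/mL; on this read-out higher numbers stand for a stronger effect at the one concentration tested and lower numbers for a weaker effect:
compound 1, `CC(=O)c1ccc(NC(=O)C(CC(C)C)N(C(=O)c2ccccc2)S(=O)(=O)c2ccc([N+](=O)[O-])cc2)cc1`, gives 71%
compound 2, `CC(=O)c1ccc(NC(=O)C2CC(O)CN2S(=O)(=O)c2ccc([N+](=O)[O-])cc2)cc1`, gives 60.1%
compound 3, `CC(=O)c1ccc(NC(=O)C(CC(C)C)N(C(=O)c2ccccc2)S(=O)(=O)c2ccccc2)cc1`, gives 46.9%

The difference between the core of compound 1 and the core of compound 2 is not broken down here. Compound 1 gives the highest number, compound 2 the second highest and compound 3 the lowest. Going by the values given here, the one counted change within the measured set is hydrogen in place of nitro on an aromatic carbon, and it made the step of a number 24.1 percentage points lower from compound 1 to compound 3 (beyond the scatter).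

Compound 4, `CC(=O)c1ccc(NC(=O)C2CC(O)CN2S(=O)(=O)c2ccccc2)cc1`, is not yet measured. It differs from compound 2 by hydrogen in place of nitro on an aromatic carbon. This change occurs twice among the compounds shown, and the place is the same in both cases, so it is the same change as from compound 1 to compound 3, carried out on the core of compound 2 instead.

Among the compounds with values here, a step of about the same size is expected from this change, a number 24.1 percentage points lower from compound 2 to compound 4 (beyond the scatter) in this assay, because the one measured instance of it gave a number 24.1 percentage points lower from compound 1 to compound 3 (beyond the scatter). Within the data shown here, with only a single precedent the range is kept wide. Compound 4 is therefore estimated at 36%, between 20% and 52%.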

Compound 4, a percentage reported as inhibition, at one concentration (the size of the read-out at that concentration, not a potency): 54.5%
Compound 4: the middle estimate sits 18.5 percentage points below what was measured, and the stated range ends below it.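

In this assay the change from 4-nitrophenyl to phenyl gives a number 5.6 percentage points lower from compound 2 to compound 4 (within the scatter), so on this core no step beyond the scatter can be read from it. The size of the step therefore does not carry over unchanged from one core to another in this series: the same change on two cores in this assay, a number 24.1 percentage points lower (beyond the scatter) from compound 1 to compound 3 and a number 5.6 percentage points lower (within the scatter) from compound 2 to compound 4, 18.5 percentage points apart, beyond the scatter of two such steps

Going by these compounds alone, this rests on only two cores, which differ from each other in more than one place, so it shows that the core matters to the size of the step but not which part of the core does so, nor how the step would behave on a third core.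

The compounds shown carry only nitro or hydrogen at this place, leaving open whether an amine, a carboxylic acid or a methoxy group there would follow the larger step or the smaller one. Also open is what the parts that separate the two cores contribute on their own, since no pair shown changes one of them alone.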